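A Methoxy Group Added to the Ring of Compound 2

A few compounds are considered here, and "the series" means these few. Any claim that something is new, unique, unknown or untested is made for them only; others in the source may bear on it.

Of the compounds shown here, three have been measured in an in vitro assay on cells for inhibition of Amine oxidase [flavin-containing] A (Homo sapiens), read by Amplex Red, with a stated time of 15 min; a lower number here means a stronger inhibitor, a higher number a weaker inhibitor. Compound 1 `COc1cc(/C=C/C(O)=C/C(=O)c2c(O)cccc2OC)ccc1O` gives 3760 nM. Compound 2 `COc1cc(/C=C/C=C/C(=O)c2ccccc2O)ccc1O` gives 1560 nM, and compound 3 `O=C(/C=C/C=C/c1ccc(Cl)cc1)c1ccc(O)cc1O` gives 15400 nM. Among these three numbers compound 2 has the lowest and is thus the strongest inhibitor of the set; compound 1 stands nearest to it with a higher number that lies beyond the usual scatter, and compound 3 stands furthest away, also beyond the scatter. Within the data shown here, no two measured compounds differ from each other in only one place, so no single structural change has yet been tied to a change in this assay.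

Compound 4 `COc1cc(/C=C/C=C/C(=O)c2c(O)cccc2OC)ccc1O` has not been measured. It differs from compound 2 by methoxy in place of hydrogen on an aromatic carbon. Compound 1 carries the same methoxy group, but the rest of its structure also differs from compound 2, so the two values of compound 1 and compound 2 cannot be read as the effect of the methoxy alone. Among the measured compounds shown here, with no measured pair showing this change on its own, a step of a 1.6-fold higher number from compound 2 to compound 4 (0.20 log units; within the scatter) is estimated, toward a somewhat higher number or none beyond the scatter. Compound 4 is expected to give about 2500 nM in this assay, within a range from 1000 nM to 6500 nM.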

Compound 4, half-maximal inhibitory concentration: 1030 nM
Beside the measured number, compound 4's estimate is 2.4-fold (0.39 log units) above it; measured number inside the range.
By their numbers in this assay, from the lowest: compounds 4 and 2 (each within the scatter of the next); then compound 1; then compound 3.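

In this assay methoxy in place of hydrogen on an aromatic carbon, ortho to a large group and meta to a hydroxy group, gives a 1.5-fold lower number from compound 2 to compound 4 (0.18 log units; within the scatter) and this step lies within the usual scatter, so the number shows no change that can be told apart from repeat measurements. Among these compounds, compound 4 also supplies the first reading of a change in the chain: hydrogen in place of hydroxy on a double-bonded chain carbon bound to two double-bonded chain carbons gives a 3.7-fold lower number from compound 1 to compound 4 (0.56 log units; beyond the scatter) and this modest step lies beyond the scatter, so here a single change in the structure is tied to a real difference in the number. Nothing at hand offers a measured reason for the size of either step.

As far as these compounds go, at the aromatic carbon only hydrogen and methoxy can be compared, so it remains open how the number would respond to a longer ether such as ethoxy, to a chlorine atom or to an amine. At the chain carbon only hydroxy and hydrogen can be compared, which leaves a methyl group or a fluorine atom there as open questions.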